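Methylsulfanyl for methoxy: expected cytotoxicity of compound 3

The source may report more compounds than this note shows. Statements on the series, on what has been measured and on what is new or still open speak of the compounds shown alone.

Compound 1 `COc1ccc(CNc2nc([Se]C)nc3ccccc23)cc1`: > 100000 nM
Compound 2 `COc1ccc(CNc2nc(SC)nc3ccccc23)cc1`: > 100000 nM

In a functional assay on MCF7 cells (Homo sapiens) for cytotoxicity, read by MTT assay, with a stated time of 72 h (on this read-out lower numbers stand for higher toxicity in this test and higher numbers for lower toxicity in this test), compound 1 gives > 100000 nM, which is a limit of the assay and not a number. In this assay compound 2 gives > 100000 nM, also a limit. The step that the two limits leave unreadable from compound 1 to compound 2 cannot be read, as the limit of > 100000 nM in this assay, at which 2 of the 2 values shown sit, shows. Compound 3 `CSc1ccc(CNc2nc([Se]C)nc3ccccc23)cc1` differs from compound 1 by methylsulfanyl in place of methoxy on an aromatic carbon. Only the unreadable step from compound 1 to compound 2 bears on this change, so no size can be drawn from it. Compound 3 is therefore expected at 100000 nM (range 30000 nM to 300000 nM), probably again as a limit, an estimated step of a number no higher from compound 1 to compound 3 (the limit leaves the size open).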

Compound 3, concentration lethal to 50% of the cells: > 100000 nM
Compound 3 ended at the assay's limit; the forecaster's own chance of this, stated with the estimate: 80%; the middle value lies on the limit itself.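

Compound 1 and compound 3 both sit at a limit of this assay, not at a number, so no step between them can be read: the limit of > 100000 nM in this assay, at which 3 of the 3 values shown sit.

The compounds shown leave open whether methylsulfanyl in place of methoxy alters toxicity to these cells at all.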